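Working notes: linker change from compound 1 to compound 3

The compounds below may be only part of what the source reports. "The series", "measured", "known", "first", "only" and "open" are said of these compounds alone.

Measured so far:
compound 1, `Cc1c(OCCCCOCOc2ccc(C(=O)O)cc2)ccc(C(=O)CC2CCCC2)c1O`, 228 nM
compound 2, `CCC(=O)c1ccc(OCCCCOc2cccc(C(=O)O)c2C)c(C)c1O`, 62 nM

In an assay on HEK293 cells for positive allosteric modulation of metabotropic glutamate receptor 2 (Rattus norvegicus), read by thallium flux, with a stated time of 2.5 min (a higher number here means that more compound is needed for the effect, a lower number that less compound is needed), compound 1 gives 228 nM, the higher of the two numbers seen in the series. Compound 2 gives 62 nM, a gap that lies beyond the usual scatter. Compound 3, `Cc1cc(C(=O)O)ccc1OCCCCOc1ccc(C(=O)CC2CCCC2)c(O)c1C`, has not been measured; relative to compound 1 it carries the change (4-carboxy-2-methylphenyl in place of (4-carboxyphenoxy)methyl on an oxygen on a saturated carbon). The chain between the two aromatic rings in compound 3 thereby resembles that of compound 2, which at both ends joins the aromatic ring directly to the oxygen of the chain. On that basis compound 3 is expected to give a lower number than compound 1 in this assay, with the step of a 2.5-fold lower number from compound 1 to compound 3 (0.40 log units; beyond the scatter) expected to fall beyond the scatter. Compound 3 is therefore estimated at 90 nM, with an expected range from 40 nM to 250 nM.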

Compound 3, half-maximal effective concentration: 608 nM
Compound 3: the middle estimate sits 6.8-fold (0.83 log units) below what was measured; measured number above the stated range.
By their numbers in this assay, from the lowest: compound 2; then compound 1; then compound 3.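

In this assay, the step to 4-carboxy-2-methylphenyl in place of (4-carboxyphenoxy)methyl on an oxygen on a saturated carbon gives a 2.7-fold higher number from compound 1 to compound 3 (0.43 log units; beyond the scatter) and so shows a modest loss of potency at this place. Among the compounds shown here, this is the first single-place comparison, but it changes two things at once: the group that enters has one oxygen fewer and carries a methyl on the aromatic ring. No measurement bears on the reason for the step.

Compound 2 differs from compound 1 and from compound 3 in more than one place, so steps to it cannot be read. The compounds shown leave open how the loss divides between the oxygen and the methyl, which a plain 4-carboxyphenyl on the same oxygen would help separate.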